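Lengthening the Hydrazone Chain: Expectation for Compound 4

The source may report more compounds than this note shows. Statements on the series, on what has been measured and on what is new or still open speak of the compounds shown alone.

Measured so far in an assay on isolated protein for inhibition of Amine oxidase [flavin-containing] B (Homo sapiens), read by fluorescence, with a stated time of 20 min; a higher number here means a weaker inhibitor, a lower number a stronger inhibitor:
Compound 1 `CC/C(C)=N\Nc1nc(-c2cccc([N+](=O)[O-])c2)cs1` gives 351 nM.
Compound 2 `CCC(CC)=NNc1nc(-c2cccc([N+](=O)[O-])c2)cs1` gives 53 nM.
Compound 3 `C=CCC/C(C)=N\Nc1nc(-c2cccc([N+](=O)[O-])c2)cs1` gives 101 nM.

Compound 3 stands with the step of a 3.5-fold lower number from compound 1 to compound 3 (0.54 log units; beyond the scatter) beyond the scatter, while compound 2 and compound 3 lie within the scatter of each other (a 1.9-fold higher number from compound 2 to compound 3 (0.28 log units; within the scatter)). Compound 4 `CCC/C(CC)=N\Nc1nc(-c2cccc([N+](=O)[O-])c2)cs1` differs from compound 3 by a group of 7 heavy atoms (6 carbon, 1 nitrogen; no ring) in place of a group of 7 heavy atoms (6 carbon, 1 nitrogen; no ring), on a nitrogen on an aromatic ring. Among the compounds with values here, two measured steps bear on this: a 6.6-fold lower number from compound 1 to compound 2 (0.82 log units; beyond the scatter) showed that adding one chain carbon gave a lower number, and a 1.9-fold higher number from compound 2 to compound 3 (0.28 log units; within the scatter) stayed within the scatter. A small step, if any, toward a lower number is therefore expected, and the estimate for compound 4 is 60 nM, ranging from 25 nM to 150 nM, which means an expected step of a 1.7-fold lower number from compound 3 to compound 4 (0.23 log units; within the scatter).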

Compound 4, half-maximal inhibitory concentration: 189 nM
The estimate for compound 4 lay 3.2-fold (0.50 log units) below the measured number; the whole stated range lies below it.
By their numbers in this assay, from the lowest: compounds 2, 3, 4 and 1 (each within the scatter of the next, the first and the last beyond it).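

In this assay, more chain carbon does not keep helping: after the gain in (a 6.6-fold lower number from compound 1 to compound 2 (0.82 log units; beyond the scatter)), one added methyl gives a weaker inhibitor (a 3.6-fold higher number from compound 2 to compound 4 (0.55 log units; beyond the scatter)). Two other steps stay within the scatter (a 1.9-fold higher number from compound 3 to compound 4 (0.27 log units; within the scatter); a 1.9-fold lower number from compound 1 to compound 4 (0.27 log units; within the scatter)), so these pairs cannot be ordered. From the compounds shown here alone, whether a still longer chain, a cyclohexyl ring or an amine on this chain would change the number remains open. Nothing available explains why the added methyl weakens inhibition.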